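Removing the piperidinylmethyl arm from compound 1

This account rests on a few compounds, and the source may have more. Where it says the series, first, only, none or still open, it means among the compounds named here.

Measured compounds:
- compound 1, `CN1CCC(CNc2ccc3[nH]nc(-c4cnn(C)c4)c3c2)CC1`: 1850000 nM
- compound 2, `FC(F)(F)c1cccc2[nH]ncc12`: 184000 nM
- compound 3, `Cn1cc(-c2nn(C)c3cc(N)ccc23)cn1`: a limit, > 384000 nM

In an assay on isolated protein for inhibition of tyrosine-protein kinase receptor UFO (Homo sapiens), with a stated time of 1.5 h (on this read-out lower numbers stand for stronger inhibition and higher numbers for weaker inhibition), compound 1 gives 1850000 nM, the highest of the two numbers in hand. Compound 2 sits nearest with 184000 nM, a lower number, and the gap between the two is beyond the usual scatter. Compound 3 does not give a number at all; its result is only a limit, > 384000 nM, the single limit among the three values shown (the limit of > 384000 nM in this assay, at which 1 of the 3 values shown sits).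

Compound 4, `Cn1cc(-c2n[nH]c3ccc(N)cc23)cn1`, is not yet measured. It differs from compound 1 in one place: hydrogen in place of (1-methylpiperidin-4-yl)methyl on a nitrogen on an aromatic ring. The free amine that results resembles the amine in compound 3, whose result is a limit, and nothing in the data ties the piperidinylmethyl arm of compound 1 to a measured effect. Compound 4 is therefore expected to stay in the weak range, at an estimated 800000 nM, between 200000 nM and 3000000 nM. The expected step of a 2.3-fold lower number from compound 1 to compound 4 (0.36 log units; beyond the scatter) would be modest, toward a somewhat lower number, and might well fall within the scatter, with a real chance that this assay again reports only a limit.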

Compound 4, half-maximal inhibitory concentration: 8910 nM
Beside the measured number, compound 4's estimate is 90-fold (1.95 log units) above it; measured number below the stated range.
By their numbers in this assay, from the lowest: compound 4; then compound 2; then compound 1.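

In this assay, replacing the (1-methylpiperidin-4-yl)methyl group on a nitrogen on an aromatic ring with hydrogen gives a 210-fold lower number from compound 1 to compound 4 (2.32 log units; beyond the scatter), the first step that can be read among these compounds. It shows that this position is highly sensitive to what it carries, and that in this pair the group of 8 heavy atoms, with its six-membered non-aromatic ring, goes with the much weaker inhibition, while the unsubstituted amine of compound 4 reaches a far lower number. No measurement shown here gives a reason for the size of this step.

What remains open is which part of the departing group accounts for the difference, since a single pair cannot separate the ring, its nitrogen and the linking carbon from one another. Nor do these compounds show whether a small ethyl or acetyl group on the same nitrogen would stay close to compound 4 or move back towards compound 1, or whether a short chain ending in an amine would behave like the full group.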